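Fluoro for chloro on the aryl group of compound 2

The source may hold more compounds than are shown below. What is called first, only, known or untested is meant among the compounds shown, and "the series" means these compounds.

Two compounds of the series have been run in a functional assay on MGC-803 cells (Homo sapiens) for antiproliferative activity, read by CCK-8 assay, with a stated time of 72 h, tested at 8 uM; on this read-out higher numbers stand for a stronger effect at the one concentration tested and lower numbers for a weaker effect. Compound 1 `Nc1ccccc1NC(=O)c1ccc(CSC(=S)N2CCN(C(c3ccccc3)c3ccccc3)CC2)cc1` gives 9.9%, and compound 2 `Nc1ccccc1NC(=O)c1ccc(CSC(=S)N2CCN(c3ccc(Cl)cc3)CC2)cc1` gives 17.2%. Compound 2 holds the higher of the two numbers, yet its gap to compound 1 lies within the scatter, so no order between the two can be read from these values. Compound 3 `Nc1ccccc1NC(=O)c1ccc(CSC(=S)N2CCN(c3ccc(F)cc3)CC2)cc1` has not yet been run in this assay. It differs from compound 2 in one place: fluoro in place of chloro on an aromatic carbon. Going by the values given here, no measured pair shows what this kind of exchange does, and the exchange is small in what it counts. The expectation is therefore a step no larger than the scatter, and the estimated step of a number 1.2 percentage points lower from compound 2 to compound 3 (within the scatter) in this assay is set close to zero. Compound 3 is expected to give about 16% in this assay, with a range from 6% to 28%.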

Compound 3, a percentage reported as inhibition, at one concentration (the size of the read-out at that concentration, not a potency): 48.7%
Estimate against measurement, compound 3: 32.7 percentage points below; the whole stated range lies below it.
By their numbers in this assay, from the lowest: compounds 1 and 2 (each within the scatter of the next); then compound 3.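

The aryl position of compound 2 proves sensitive: in this assay, 4-chlorophenyl to 4-fluorophenyl gives a number 31.5 percentage points higher from compound 2 to compound 3 (beyond the scatter), although one halogen atom simply replaces another and the counted donors, acceptors and net charge stay the same. A single exchange on an aromatic carbon para to a large group can therefore change the size of the effect at the one concentration tested, well beyond the scatter. Nothing shown explains this step.

From the compounds shown here alone, whether the gain belongs to fluoro itself or to the departure of chloro remains open, and a plain hydrogen at this place would help to separate the two. Going by these compounds, it is also open whether a methoxy group or an amine here would stay near compound 2 or near compound 3.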